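Swapping Ethyl for Bromo on a Small Lipophilicity Series

The compounds below may be only part of what the source reports. "The series", "measured", "known", "first", "only" and "open" are said of these compounds alone.

Measured so far in a physicochemical assay for lipophilicity; on this read-out lower numbers stand for lower lipophilicity and higher numbers for higher lipophilicity:
- compound 1 `CCc1cc2nc(O)c(O)nc2c([N+](=O)[O-])c1Br` gives 1.04
- compound 2 `CCc1cc2nc(O)c(O)nc2c([N+](=O)[O-])c1Cl` gives 0.92

Compound 1 has only compound 2 for comparison, and the two sit within the scatter of each other. Among the compounds with values here, the single measured step is a number 0.12 log units lower from compound 1 to compound 2 (within the scatter), which puts chloro in place of bromo on an aromatic carbon.

The unmeasured compound 3 `O=[N+]([O-])c1c(Br)c(Br)cc2nc(O)c(O)nc12` differs from compound 1 by bromo in place of ethyl on an aromatic carbon, ortho to a bromo group. Within the data shown here, no measured step replaces ethyl, so the small chloro-for-bromo step offers only a loose guide. On that guide, little movement is expected, perhaps slightly downward. The expected step is a number 0.09 log units lower from compound 1 to compound 3 (within the scatter) in this assay, no larger than the scatter. For compound 3 the estimate is 0.95, with an expected range from 0.55 to 1.35.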

Compound 3, partition coefficient: 0.74
Compound 3: middle estimate off by 0.21 log units, on the high side; low and high end bracket the measured number.
By their numbers in this assay, from the lowest: compounds 3, 2 and 1 (each within the scatter of the next).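

Within the data shown here, compounds 1 and 2 differ only in the halogen, so this is the first look at the aromatic carbon that carries the ethyl group, ortho to a bromo group. Read by this assay, bromo in place of ethyl gives a number 0.30 log units lower from compound 1 to compound 3 (within the scatter), so ethyl and bromo cannot be told apart here, even though two heavy atoms leave and one enters. No evidence is available that bears on this result.

The compounds shown leave open whether any group on this carbon would move the number beyond the scatter, such as a longer chain like propyl, an amine or a carboxylic acid. They also leave open whether this step would look the same with chloro in place of the bromo group ortho to this carbon.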